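The source may hold more compounds than are shown below. What is called first, only, known or untested is meant among the compounds shown, and "the series" means these compounds.

Measured compounds in this series:
compound 1 `CCOc1ccc(NC2=CC(=O)c3c(nc4n3[C@H]3OC[C@@H](O)[C@H]3OC4)C2=O)cc1` — > 4000 nM
compound 2 `O=C1C=C(Nc2ccc(C(F)(F)F)cc2)C(=O)c2c1nc1n2[C@H]2OC[C@@H](O)[C@H]2OC1` — > 4000 nM
compound 3 `O=C1C=C(Nc2cccc(Cl)c2)C(=O)c2c1nc1n2[C@H]2OC[C@@H](O)[C@H]2OC1` — 4720 nM

In a functional assay on MCF7 cells (Homo sapiens) for inhibition, read by sulforhodamine B assay (on this read-out lower numbers stand for stronger inhibition and higher numbers for weaker inhibition), compound 1 returns only a limit, > 4000 nM, so no number stands for it. Compound 2 likewise returns a limit, > 4000 nM. Within the data shown here, compound 3 is the only one with a number, 4720 nM. Among the measured compounds shown here, the single step computed between measured compounds, a step that the limit leaves unreadable from compound 2 to compound 3, cannot be sized because of the limit of > 4000 nM in this assay, at which 2 of the 3 values shown sit. For the measured compounds named here, nothing among the measured values therefore shows how a change of the aryl group on the amine nitrogen moves this read-out.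

Compound 4 `O=C1C(Nc2ccccc2F)=CC(=O)c2c1nc1n2[C@H]2OC[C@@H](O)[C@H]2OC1` differs from compound 1 by 2-fluorophenyl in place of 4-ethoxyphenyl on an amine nitrogen. Going by the values given here, no measured step covers this exchange; the three aryl variants tested all sit at or near the limit of the assay, and the one computed step is unreadable. The expectation is therefore that compound 4 also lands close to the limit, with no step beyond scatter: the estimated step that the limit leaves unreadable from compound 1 to compound 4 is treated as essentially flat. For compound 4 the estimate is 5000 nM, within 2000 nM to 20000 nM, with a substantial chance that the assay again reports only a limit.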

Compound 4, half-maximal inhibitory concentration: > 4000 nM
Compound 4: only a limit was reported; the forecaster's own chance of this, stated with the estimate: 60%; the middle value lies beyond the limit too.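

In this assay compound 4 returns > 4000 nM, which is a limit and not a number. The exchange of 4-ethoxyphenyl for 2-fluorophenyl between compound 1 and compound 4 therefore gives no readable step, because both compounds sit at a limit: the limit of > 4000 nM in this assay, at which 3 of the 4 values shown sit.

Still open, on these data alone, is how far any change of the aryl group on the amine nitrogen moves the read-out in this assay.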